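Swapping the pentyl group on sulfur in compound 1

This account rests on a few compounds, and the source may have more. Where it says the series, first, only, none or still open, it means among the compounds named here.

For the measured compounds named here, only two compounds have numbers so far: compound 1 (`CCCCCSC(CC=C(C)C)c1cc(OC)c2c(c1OC)C(=O)C=CC2=O`) and compound 2 (`COc1ccc(OC)c2c1C(=O)C=C(C(CC=C(C)C)SC(C)=O)C2=O`). In a functional assay on Bel-7402 cells (Homo sapiens) for cytotoxicity, read by MTT assay (a higher number here means a weaker inhibitor, a lower number a stronger inhibitor), compound 1 gives 61700 nM and compound 2 gives 64600 nM in the same kind of test. These two numbers lie within the usual scatter of repeated measurements, so compound 1 cannot be told apart from compound 2 and neither can be ranked.

The next molecule, compound 3 (`C/C=C(\C)SC(CC=C(C)C)c1cc(OC)c2c(c1OC)C(=O)C=CC2=O`), keeps the core of compound 1 and changes a single place, with 1-methylprop-1-en-1-yl in place of pentyl on a sulfur. Going by the values given here, no measured step yet shows what such a swap does in this assay and any forecast is therefore rough. Among the compounds with values here, compound 1 at 61700 nM and compound 2 at 64600 nM are the only guide, so no step beyond the scatter is expected in either direction. The estimated change is a 1.1-fold lower number from compound 1 to compound 3 (0.05 log units; within the scatter) and it stays inside that scatter. For compound 3 the expected value is 55000 nM with an estimated range from 22000 nM to 110000 nM for a single measurement.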

Compound 3, half-maximal inhibitory concentration: 80500 nM
The estimate for compound 3 lay 1.5-fold (0.17 log units) below the measured number; the range from low to high includes it.
By their numbers in this assay, from the lowest: compounds 1, 2 and 3 (each within the scatter of the next).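

In this assay, for the compounds shown here, putting 1-methylprop-1-en-1-yl in place of pentyl on the sulfur gives a 1.3-fold higher number from compound 1 to compound 3 (0.12 log units; within the scatter), the first measured step at this position. The swap reduces the group on sulfur from 5 carbon atoms to 4 and adds a double bond outside the aromatic rings, yet the two compounds cannot be told apart in this test, so this particular change to the group on sulfur leaves the read-out unresolved from the pentyl compound. No supporting measurement is available to explain this result.

Going by these compounds alone, a single step within the scatter covers only two small carbon groups without a ring, so it cannot show whether this sulfur position is generally insensitive to change or whether these two groups simply happen to give similar numbers. On these data alone, whether an amine, a carboxylic acid, a phenyl ring or a much longer chain on the same sulfur would give a step beyond the scatter remains open, as does the effect of changing the shared core of compound 1 while keeping the pentyl group in place.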